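The source may hold more compounds than are shown below. What is called first, only, known or untested is meant among the compounds shown, and "the series" means these compounds.

Compound 1 `CC(C)n1nc(-c2ccon2)c2c(N)ncnc21`: 8940 nM
Compound 2 `CC(C)n1nc(-c2cc(C(C)(C)C)on2)c2c(N)ncnc21`: 7310 nM
Compound 3 `CC(C)c1cc(-c2nn(C(C)C)c3ncnc(N)c23)no1`: 5900 nM

These three compounds share one core and differ only in the group carried on the five-membered aromatic ring with 1 nitrogen and 1 oxygen. In an assay on BaF3 cells for inhibition of proto-oncogene tyrosine-protein kinase receptor Ret variant V804M (Homo sapiens), read by MTT assay, with a stated time of 48 h (on this read-out lower numbers stand for stronger inhibition of growth and higher numbers for weaker inhibition of growth), compound 3 gives the lowest of the three numbers, yet the gaps to the others are small: a 1.2-fold lower number from compound 2 to compound 3 (0.09 log units; within the scatter) and a 1.5-fold lower number from compound 1 to compound 3 (0.18 log units; within the scatter), both within the scatter, so no order among the three can be claimed.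

Compound 4 `CC(C)n1nc(-c2cc(-c3ccc(F)cc3)on2)c2c(N)ncnc21` carries the change (4-fluorophenyl in place of isopropyl on an aromatic carbon). The measured steps that bear on it are the two additions of a group at that carbon, a 1.2-fold lower number from compound 1 to compound 2 (0.09 log units; within the scatter) and a 1.5-fold lower number from compound 1 to compound 3 (0.18 log units; within the scatter), and the exchange a 1.2-fold lower number from compound 2 to compound 3 (0.09 log units; within the scatter); none of them moved this assay beyond the scatter. Only small alkyl groups have been tried there, so a 4-fluorophenyl is a larger departure and the uncertainty is wider. The expected step is therefore a 1.3-fold lower number from compound 3 to compound 4 (0.12 log units; within the scatter) for compound 4. Compound 4 is estimated at 4500 nM in this assay, with a range from 1200 nM to 15000 nM.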

Compound 4, concentration for 50% growth inhibition: > 10000 nM
Compound 4: only a limit was reported (the forecaster's own chance of this, stated with the estimate: 5%); middle value at least 2.2-fold (0.34 log units) away from the limit.
By their numbers in this assay, from the lowest: compounds 3, 2 and 1 (each within the scatter of the next). At a limit, above all of these: compound 4.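

For compound 4, the > 10000 nM reported in this assay is a limit, not a number. For the compounds shown here, this is the first time a group carrying its own ring, the 4-fluorophenyl, stands on this aromatic carbon, and it brings no lower number than hydrogen, isopropyl or tert-butyl. Going by these compounds alone, the steps give only floors, an at least 1.6-fold higher number from compound 3 to compound 4 (0.22 log units; that floor lies within the scatter), an at least 1.3-fold higher number from compound 2 to compound 4 (0.13 log units; that floor lies within the scatter) and an at least 1.1-fold higher number from compound 1 to compound 4 (0.04 log units; that floor lies within the scatter), so compound 4 cannot be set apart from the earlier compounds, and how far its true number lies beyond the limit stays unknown.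

The compounds shown leave open whether the ring itself or its fluorine sets this result, which a plain phenyl would help to separate. They also leave open how an amine, a carboxylic acid or a longer chain would behave at this carbon.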